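Vinyl for ethoxycarbonyl swap on two side chains

A few compounds are considered here, and "the series" means these few. Any claim that something is new, unique, unknown or untested is made for them only; others in the source may bear on it.

Measured so far:
compound 1 `C=CCc1ccc(OC)c(-c2cc(COCC(=O)OCC)on2)c1` — 25900 nM
compound 2 `C=CCOCc1cc(-c2cc(CC=C)ccc2OC)no1` — 28700 nM
compound 3 `C=CCc1ccc(OC)c(-c2cc(CN3CCN(CC(=O)OCC)CC3)on2)c1` — > 200000 nM

In a functional assay on BV-2 cells (Mus musculus) for inhibition, read by Griess assay, with a stated time of 24 h (a lower number here means a stronger inhibitor, a higher number a weaker inhibitor), compound 1 gives 25900 nM and compound 2 gives 28700 nM. Compound 2 differs from compound 1 by vinyl in place of ethoxycarbonyl on a saturated chain carbon bound to an oxygen on a saturated carbon, and the step is a 1.1-fold higher number from compound 1 to compound 2 (0.04 log units; within the scatter). Compound 3 gives only a limit in this assay, > 200000 nM. The difference between the cores of compound 1 and compound 3 is not broken down here.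

Compound 4 `C=CCc1ccc(OC)c(-c2cc(CN3CCN(CC=C)CC3)on2)c1`, not yet measured, differs from compound 3 by vinyl in place of ethoxycarbonyl on a saturated chain carbon bound to an amine nitrogen in a ring. This is the same kind of change as before, though the place now is on a saturated chain carbon bound to an amine nitrogen in a ring rather than on a saturated chain carbon bound to an oxygen on a saturated carbon. The expected step is a step that the limit leaves unreadable from compound 3 to compound 4, taken as small because the earlier step was a 1.1-fold higher number from compound 1 to compound 2 (0.04 log units; within the scatter) and because compound 3 sits at the limit of > 200000 nM in this assay, at which 1 of the 3 values shown sits. For compound 4 in this assay the estimate is 250000 nM, with a range from 70000 nM to 900000 nM, most likely reported again only as a limit.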

Compound 4, half-maximal inhibitory concentration: 111000 nM
Beside the measured number, compound 4's estimate is 2.3-fold (0.35 log units) above it; the measured number falls inside the stated range.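

In this assay, vinyl in place of ethoxycarbonyl on a saturated chain carbon bound to an amine nitrogen in a ring gives an at least 1.8-fold lower number from compound 3 to compound 4 (0.25 log units; that floor lies within the scatter). Compound 3 stands only as a limit, > 200000 nM, and the step is therefore a floor, not a full size. Whether the change carries over from one core to the other with the same size remains undecided: the same change on two cores in this assay, a 1.1-fold higher number (0.04 log units; within the scatter) from compound 1 to compound 2 and an at least 1.8-fold lower number (0.25 log units; that floor lies within the scatter) from compound 3 to compound 4; the limit leaves it open whether they differ

The compounds shown leave open how far this step runs past its floor. Also open, going by these compounds, is what a carboxylic acid in place of ethoxycarbonyl, or a longer chain in place of vinyl, would give on either core in this assay.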